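Working notes: 1H-indazol-4-yl in place of 1H-indazol-5-yl

A few compounds are considered here, and "the series" means these few. Any claim that something is new, unique, unknown or untested is made for them only; others in the source may bear on it.

Measured in an ADME assay on the whole organism for pharmacokinetics, with Mus musculus as the target, at a dose of 10 mg/kg by the oral route; a higher number here means more compound in the circulation at the dose given, a lower number less compound in the circulation:
- compound 1 `CC/C(=C(/c1ccc(/C=C/C(=O)O)cc1)c1ccc2[nH]c(=O)oc2c1)c1ccccc1`: 3000 ng.h/mL
- compound 2 `CC/C(=C(/c1ccc(/C=C/C(=O)O)cc1)c1ccc2[nH]ccc2c1)c1ccccc1`: 9400 ng.h/mL
- compound 3 `CC/C(=C(/c1ccc(/C=C/C(=O)O)cc1)c1ccc2[nH]ncc2c1)c1ccccc1`: 5800 ng.h/mL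

Compound 3 at 5800 ng.h/mL lies within the scatter of both other compounds. Compound 4 `CC/C(=C(/c1ccc(/C=C/C(=O)O)cc1)c1cccc2[nH]ncc12)c1ccccc1` differs from it thus: 1H-indazol-4-yl in place of 1H-indazol-5-yl on a double-bonded chain carbon bound to an aromatic carbon and a double-bonded chain carbon. Among the compounds with values here, no measured pair isolates this kind of change. The nearest evidence is a 1.6-fold lower number from compound 2 to compound 3 (0.21 log units; within the scatter) and a 1.9-fold higher number from compound 1 to compound 3 (0.29 log units; within the scatter). The largest step in the set is a 3.1-fold higher number from compound 1 to compound 2 (0.50 log units; beyond the scatter), which is still modest. No change beyond the scatter is therefore expected in this assay. The estimated step is a 1.2-fold lower number from compound 3 to compound 4 (0.06 log units; within the scatter). For compound 4 the expected value is 5000 ng.h/mL, with an estimated range of 2000 ng.h/mL to 12000 ng.h/mL.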

Compound 4, area under the concentration-time curve: 2800 ng.h/mL
Compound 4: the middle estimate sits 1.8-fold (0.25 log units) above what was measured; the measured number falls inside the stated range.
By their numbers in this assay, from the lowest: compounds 4, 1, 3 and 2 (each within the scatter of the next, the first and the last beyond it).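

In this assay, moving the attachment point of the indazole, with the atoms unchanged, gives a 2.1-fold lower number from compound 3 to compound 4 (0.32 log units; beyond the scatter) and so counts as a modest change at this place on the double-bonded chain carbon. The 1H-indazol-4-yl group also gives a 3.4-fold lower number from compound 2 to compound 4 (0.53 log units; beyond the scatter) against the 1H-indol-5-yl group, whereas a 1.1-fold lower number from compound 1 to compound 4 (0.03 log units; within the scatter) leaves it level with the group in compound 1. No measurement here bears on the reason for these steps.

Open, as far as these compounds go, is whether 1H-indol-4-yl would follow 1H-indazol-4-yl in this read-out. A methyl group on the 1H-indazol-4-yl ring is also untested in this set.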